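Working notes: replacing the aryl group on sulfur

The compounds below may be only part of what the source reports. "The series", "measured", "known", "first", "only" and "open" are said of these compounds alone.

compound 1 `COc1ccc(SCc2ccc(/C=C/C(=O)Nc3ccccc3N)cc2)cc1OC` gives 44.6% here
compound 2 `COc1ccc(SCc2ccc(C(=O)Nc3ccccc3N)cc2)cc1` gives 80.1% here

In a functional assay on SMMC-7721 cells (Homo sapiens) for inhibition, read by CCK-8 assay, with a stated time of 72 h, tested at 8 uM (on this read-out lower numbers stand for less inhibition of growth and higher numbers for more inhibition of growth at the one concentration tested), compound 2 stands highest of the two, and compound 1 lies lower by a gap beyond the usual scatter. Within the data shown here, these two compounds differ in more than one place, so no measured step speaks directly to the next change. Compound 3 `Nc1ccccc1NC(=O)c1ccc(CSc2cccc(F)c2)cc1` is the next compound to be read. Relative to compound 2 it shows 3-fluorophenyl in place of 4-methoxyphenyl on a sulfur in its structure, with 3-fluorophenyl in place of 4-methoxyphenyl on a sulfur. Compound 2 at 80.1% leaves limited room upward, so a modest fall is expected in this assay, perhaps not beyond the scatter. The estimated step of a number 10.1 percentage points lower from compound 2 to compound 3 (beyond the scatter) is small and downward. For compound 3 the expected value is 70% within an estimated range of 50% to 88% in this read-out.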

Compound 3, percent growth inhibition at one concentration: 83%
For compound 3 the middle estimate is 13 percentage points below the measured one; low and high end bracket the measured number.
By their numbers in this assay, from the lowest: compound 1; then compounds 2 and 3 (each within the scatter of the next).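

In this assay, among these compounds, the first measured step at this position runs a number 2.9 percentage points higher from compound 2 to compound 3 (within the scatter) with 3-fluorophenyl in place of 4-methoxyphenyl on a sulfur. For this pair, the level of growth inhibition seen with compound 2 therefore does not depend on keeping the 4-methoxyphenyl group, and the position accepts an aryl group carrying fluorine instead of methoxy without a change beyond the scatter. No supporting data on hand bear on why the two compounds read alike.

As far as these compounds go, whether this tolerance extends to a non-aromatic group on the sulfur, such as a longer alkyl chain, or to a phenyl group carrying a carboxylic acid remains open. A reading at one concentration also leaves open whether compound 2 and compound 3 would separate across a range of concentrations.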